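The source may hold more compounds than are shown below. What is called first, only, known or untested is meant among the compounds shown, and "the series" means these compounds.

Measured in a functional assay on THP-1 cells (Homo sapiens) for inhibition, with a stated time of 48 h, tested at 50 uM; on this read-out higher numbers stand for more inhibition of growth at the one concentration tested and lower numbers for less inhibition of growth:
Compound 1 `C=C[C@@](C)(/C=C/c1ccc(OC(=O)CC)cc1)CCC=C(C)C`: 60%
Compound 2 `C=C[C@@](C)(/C=C/c1ccc(OC(=O)CCCCCCC)cc1)CCC=C(C)C`: 62%

These two compounds share a core and differ only in the length of the chain on the carbonyl carbon. Among the measured compounds shown here, on the numbers so far, compound 2 at 62% cannot be told apart from compound 1, since the two values lie within the usual scatter of each other.

The next compound to be tested, compound 3 `C=C[C@@](C)(/C=C/c1ccc(OC(=O)CCCCCCCCC)cc1)CCC=C(C)C`, extends the same chain further. Its change is ethyl in place of hydrogen on a saturated chain carbon, seven bonds along the chain from a carbonyl carbon.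

For the measured compounds named here, only one measured step bears on this change. That step, a number 2 percentage points higher from compound 1 to compound 2 (within the scatter), was a larger addition to the same chain, and it stayed within the scatter. With just this one step as a guide, no shift beyond the scatter is expected in this assay, though a single step is thin evidence. The expected change is a number 2 percentage points lower from compound 2 to compound 3 (within the scatter). For compound 3 the estimated value is 60%, with an expected range from 47% to 72%.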

Compound 3, percent growth inhibition at one concentration: 52%
Beside the measured number, compound 3's estimate is 8 percentage points above it; the measured number falls inside the stated range.
By their numbers in this assay, from the lowest: compounds 3, 1 and 2 (each within the scatter of the next).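

In this assay, ethyl in place of hydrogen on a saturated chain carbon, seven bonds along the chain from a carbonyl carbon, gives a number 10 percentage points lower from compound 2 to compound 3 (within the scatter) and so adds a second step at this chain that stays inside the scatter, even though it is larger than the first step measured. Comparing the two ends of the series gives a number 8 percentage points lower from compound 1 to compound 3 (within the scatter) and so the shortest and longest chains shown cannot be told apart either, which means this chain has been lengthened considerably without a step beyond the scatter. No measurement is available that could account for these numbers.

The compounds shown leave open whether a still longer chain, or a chain ending in an amine or a carboxylic acid, would move the number beyond the scatter. Going by these compounds, each compound also has a reading at only one concentration, so how the three compare at other concentrations remains unknown.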